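Two Limits Reached, a Third Compound Expected at the Same Place

A few compounds are considered here, and "the series" means these few. Any claim that something is new, unique, unknown or untested is made for them only; others in the source may bear on it.

Compound 1 `Cc1ncc([N+](=O)[O-])n1CCSC(=S)N1CCC(=O)CC1`: > 1000 ug/mL
Compound 2 `Cc1ncc([N+](=O)[O-])n1CCSC(=S)N1CCC(OC(=O)CSC(=S)N2CCCC2)CC1`: > 1000 ug/mL

Both numbers are limits of the assay rather than measured values. In an ADME assay on HeLa cells (Homo sapiens) for cytotoxicity (a higher number here means a weaker inhibitor, a lower number a stronger inhibitor), compound 1 reaches only the limit > 1000 ug/mL. In this assay compound 2 also stops at a limit, > 1000 ug/mL, and so stands at the limit of > 1000 ug/mL in this assay, at which 2 of the 2 values shown sit. Within the data shown here, no step between measured compounds can be sized here. Compound 3 `Cc1ncc([N+](=O)[O-])n1CCSC(=S)N1CCC(OC(=O)C(Cl)Cl)CC1` differs from compound 2 at one place: a group of 3 heavy atoms (1 carbon, 2 chlorine; no ring) in place of a group of 9 heavy atoms (6 carbon, 1 nitrogen, 2 sulfur; one five-membered non-aromatic ring with 1 hetero atom), on a carbonyl carbon. The expected step of a number no higher from compound 2 to compound 3 (the limit leaves the size open) is none beyond the scatter. Compound 3 is therefore expected to give about 1000 ug/mL, within 400 ug/mL to 2500 ug/mL, most probably again only as a limit.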

Compound 3, half-maximal inhibitory concentration: > 1000 ug/mL
Compound 3: no number, only a limit (the forecaster's own chance of this, stated with the estimate: 80%); the middle value sits exactly at the limit.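

Among these compounds, compound 2 and compound 3 both stop at a limit, so no step between them can be read: the limit of > 1000 ug/mL in this assay, at which 3 of the 3 values shown sit.

On these data alone, the actual strength of compound 1, compound 2 and compound 3 in this assay stays open.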